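A few compounds are considered here, and "the series" means these few. Any claim that something is new, unique, unknown or untested is made for them only; others in the source may bear on it.

Working notes on the series. Compound 1 `COc1cc(OC)c2c(=O)cc(/C=C/c3ccc(Cl)cc3)oc2c1` is the starting point here. In a functional assay on A549 cells (Homo sapiens) for antiproliferative activity, read by MTT assay, with a stated time of 12 h (a lower number here means a stronger inhibitor, a higher number a weaker inhibitor), compound 1 gives only the limit > 40000 nM. Compound 3 `COc1ccc(/C=C/c2cc(=O)c3c(OC)cc(OC)cc3o2)cc1` likewise gives only the limit > 40000 nM in this assay. The step that the two limits leave unreadable from compound 1 to compound 3 is therefore not readable. Within the data shown here, compound 2 `O=c1cc(/C=C/c2ccc(OC(F)(F)F)cc2)oc2ccccc12` gives 15600 nM in this assay, the one numerical value so far. Otherwise the series sits at the limit of > 40000 nM in this assay, at which 2 of the 3 values shown sit. Compound 4 `COc1cc(OC)c2c(=O)cc(/C=C/c3ccncc3)oc2c1` has not yet been measured; the change from compound 1 is pyridin-4-yl in place of 4-chlorophenyl on a double-bonded chain carbon bound to a double-bonded chain carbon. Among the measured compounds shown here, no measured step bears on pyridin-4-yl entering in place of 4-chlorophenyl, and the only measured step starting from compound 1 is unreadable. The expected step is a number no higher from compound 1 to compound 4 (the limit leaves the size open), nothing clearly beyond the scatter. The estimate for compound 4 in this assay is 40000 nM, within 15000 nM to 100000 nM.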

Compound 4, half-maximal inhibitory concentration: > 40000 nM
Compound 4: a limit, no number; the forecaster's own chance of this, stated with the estimate: 60%; the middle value lies on the limit itself.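

Compound 4, like compound 1 and compound 3, gives only a limit in this assay, so no step among these three compounds can be read. Whether pyridin-4-yl, 4-chlorophenyl and 4-methoxyphenyl differ on the shared core in this assay stays open, with most of the series at one limit: the limit of > 40000 nM in this assay, at which 3 of the 4 values shown sit.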